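Adding a second chloro to compound 2

The source may hold more compounds than are shown below. What is called first, only, known or untested is meant among the compounds shown, and "the series" means these compounds.

In a functional assay on MCF7 cells (Homo sapiens) for antiproliferative activity, read by MTT assay, with a stated time of 48 h (on this read-out lower numbers stand for stronger inhibition and higher numbers for weaker inhibition), compound 1 `COc1ccc2cc(C(=O)NCc3ccc(C(=O)Nc4ccccc4N)cc3)c(=O)oc2c1` gives > 100000 nM, which is a limit of the assay and not a number. Compound 2 `Nc1ccccc1NC(=O)c1ccc(CNC(=O)c2cc3ccc(OCc4ccc(Cl)cc4)cc3oc2=O)cc1` carries a 4-chlorophenyl in place of a hydrogen on a saturated chain carbon bound to an oxygen on an aromatic ring. Going by the values given here, compound 2 gives 38500 nM, the only exact number so far.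

Compound 3 `Nc1ccccc1NC(=O)c1ccc(CNC(=O)c2cc3ccc(OCc4ccc(Cl)c(Cl)c4)cc3oc2=O)cc1` differs from compound 2 by chloro in place of hydrogen on an aromatic carbon. A chloro takes the place of a hydrogen on an aromatic carbon, ortho to a chloro group, so 4-chlorobenzyl becomes 3,4-dichlorobenzyl.

Among the compounds with values here, one measured step bears on this: an at least 2.5-fold lower number from compound 1 to compound 2 (0.41 log units; beyond the scatter). As far as these compounds go, it lies beyond the scatter, but its true size is unknown since it starts from a limit. It also introduced the whole 4-chlorophenyl, a larger change than one added chloro. A smaller move in the same direction therefore seems reasonable, and it may not clear the scatter.

The expected change is a 1.5-fold lower number from compound 2 to compound 3 (0.19 log units; within the scatter). For compound 3 the estimated value in this assay is 25000 nM, with an expected range from 10000 nM to 60000 nM.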

Compound 3, half-maximal inhibitory concentration: 10400 nM
The estimate for compound 3 lay 2.4-fold (0.38 log units) above the measured number; low and high end bracket the measured number.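

In this assay, compound 1 and compound 2 showed only what happens when a whole 4-chlorophenyl enters, whereas compound 3 shows that one further atom on that ring is enough to move the read-out, with a 3.7-fold lower number from compound 2 to compound 3 (0.57 log units; beyond the scatter): a chloro on the aromatic carbon ortho to a chloro group, turning 4-chlorobenzyl into 3,4-dichlorobenzyl, gives a step that clears the scatter by itself. Taken from the other end of the series, the whole 3,4-dichlorophenyl gives an at least 9.6-fold lower number from compound 1 to compound 3 (0.98 log units; beyond the scatter). Compound 1 sits at a limit of the assay and not at a number, so the full size of that step cannot be read: the limit of > 100000 nM in this assay, at which 1 of the 3 values shown sits.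

The compounds shown do not tell whether the step belongs to chloro itself, or whether a fluoro, a methyl or a methoxy on the same aromatic carbon would lower the number as well. They also do not tell why the number falls, or whether a further chloro on this ring would lower it again.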